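The compounds below may be only part of what the source reports. "The series", "measured", "known", "first", "only" and "open" are said of these compounds alone.

Compound 1 (`CCOC(=O)C1=C(Nc2ccccc2)S/C(=C\c2ccc(Br)c(O)c2)C1=O`) is the reference point for this small set. In a functional assay on A549 cells (Homo sapiens) for inhibition, read by MTT assay, with a stated time of 72 h, tested at 10 uM (a lower number here means less inhibition, a higher number more inhibition at the concentration tested (going by the name of the read-out)), compound 1 gives 13.6%. Compound 2 (`CCOC(=O)C1=C(Nc2ccccc2)S/C(=C\c2cccc(C(=O)O)c2)C1=O`) carries a 3-carboxyphenyl group in place of the 4-bromo-3-hydroxyphenyl group of compound 1. For compound 2 the read-out is only a limit, < 10%, and not a measured number. That limit is the limit of < 10% in this assay, at which 1 of the 2 values shown sits. Among the measured compounds shown here, the step of a number at least 3.6 percentage points lower from compound 1 to compound 2 (that floor lies within the scatter) is therefore the only measured change available, and it is small.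

Compound 3 (`CCOC(=O)C1=C(Nc2ccccc2)S/C(=C\c2cc[nH]c2)C1=O`) has not yet been tested. It differs from compound 2 in one place: 1H-pyrrol-3-yl in place of 3-carboxyphenyl on a double-bonded chain carbon bound to a double-bonded ring carbon. For the measured compounds named here, the single measured step, from compound 1 to compound 2, bears on this change only loosely, since it swaps one aromatic ring for another at the same position and ends at the limit. Both measured compounds sit near the bottom of the scale, so compound 3 is expected to stay low as well, with no shift beyond the scatter. Compound 3 is estimated to give 10% in this assay, ranging from 3% to 22%. That amounts to an expected step of a number no lower from compound 2 to compound 3 (the limit leaves the size open).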

Compound 3, a percentage reported as inhibition, at one concentration (the size of the read-out at that concentration, not a potency): < 10%
Compound 3 was reported as a limit (the forecaster's own chance of this, stated with the estimate: 50%); the middle value sits exactly at the limit.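

At this position, on a double-bonded chain carbon bound to a double-bonded ring carbon, a five-membered aromatic ring with a ring nitrogen now joins the two substituted phenyl groups, and in this assay the read-out again gives a limit rather than a number: the limit of < 10% in this assay, at which 2 of the 3 values shown sit.

The step between compound 2 and compound 3 joins two limits and cannot be read. Among the compounds shown here, the only readable step for this new group is a number at least 3.6 percentage points lower from compound 1 to compound 3 (that floor lies within the scatter), so neither the smaller 1H-pyrrol-3-yl ring nor the loss of the 4-bromo-3-hydroxyphenyl group can be said to have changed the read-out beyond the scatter.

On these data alone, how far compound 2 and compound 3 truly differ stays unknown, since limits give no numbers to set side by side. Also open, as far as these compounds go, is whether a quite different group at this place, such as a phenyl ring carrying an amine or a longer alkyl chain, would lift the read-out clearly above the values seen for these three compounds.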